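Adding a hydroxy group to compound 2

This account rests on a few compounds, and the source may have more. Where it says the series, first, only, none or still open, it means among the compounds named here.

Measured in a functional assay on SW480 cells (Homo sapiens) for antiproliferative activity, read by sulforhodamine B assay, with a stated time of 48 h; a higher number here means a weaker inhibitor, a lower number a stronger inhibitor:
compound 1 `COc1ccc(/C=C/C(=O)c2ccccc2-c2ccc(F)cc2)cc1O`: 57 nM
compound 2 `COc1ccc(/C=C/C(=O)c2ccccc2-c2cccc(F)c2)cc1`: 140 nM
compound 3 `COc1ccc(/C=C/C(=O)c2ccccc2-c2cccnc2)cc1`: 200 nM

Compound 2, at 140 nM, lies within the usual scatter of compound 3, while its number is clearly higher than that of compound 1. Compound 4 `COc1ccc(/C=C/C(=O)c2ccccc2-c2cccc(F)c2)cc1O` has hydroxy in place of hydrogen on an aromatic carbon, ortho to a methoxy group: hydroxy in place of hydrogen on an aromatic carbon.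

Among the measured compounds shown here, the only measured single-place step, a 1.4-fold higher number from compound 2 to compound 3 (0.15 log units; within the scatter), concerns a different change, pyridin-3-yl in place of 3-fluorophenyl, so it says little about this one. The better guide is compound 1, which carries the hydroxy and gives 57 nM. For the measured compounds named here, its fluorine sits differently from that of compound 2, however, so the gap between these two cannot be credited to the hydroxy alone, and no measured pair isolates that group. A move toward a lower number in this assay is therefore expected, though on thin evidence. The expected size is a 2.2-fold lower number from compound 2 to compound 4 (0.33 log units; beyond the scatter). For compound 4 the estimated value is 65 nM, with an expected range of 25 nM to 160 nM.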

Compound 4, half-maximal inhibitory concentration: 10 nM
The estimate for compound 4 lay 6.5-fold (0.81 log units) above the measured number; measured number outside the range, below it.
By their numbers in this assay, from the lowest: compound 4; then compound 1; then compounds 2 and 3 (each within the scatter of the next).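

In this assay, a 14-fold lower number from compound 2 to compound 4 (1.15 log units; beyond the scatter) now isolates the effect of adding a hydroxy group ortho to the methoxy group, since these two compounds differ in nothing else. Fluorine placement also matters when this hydroxy group is present: with 3-fluorophenyl in place of 4-fluorophenyl, there is a 5.7-fold lower number from compound 1 to compound 4 (0.76 log units; beyond the scatter), a change that the earlier compounds could not separate from the effect of the hydroxy group. Nothing measured here gives a reason for either step.

On these data alone, it remains open whether the hydroxy group would bring a similar gain to compound 3, which carries pyridin-3-yl instead of a fluorophenyl group. It is also unknown whether an amine or a longer ether chain such as ethoxy could take the place of the hydroxy group and keep the low number of compound 4.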